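The source may hold more compounds than are shown below. What is called first, only, known or untested is meant among the compounds shown, and "the series" means these compounds.

Two compounds have been measured in a functional assay on HeLa cells (Homo sapiens) for antiproliferative activity, read by CCK-8 assay, with a stated time of 72 h, tested at 8 uM; on this read-out higher numbers stand for a stronger effect at the one concentration tested and lower numbers for a weaker effect:

compound 1, `Nc1ccccc1NC(=O)c1ccc(CSC(=S)N2CCN(C3CCCCC3)CC2)cc1`, gives 76.1%
compound 2, `Nc1ccccc1NC(=O)c1ccc(CSC(=S)N2CCc3ccc([N+](=O)[O-])cc32)cc1`, gives 62.1%

Of these two numbers compound 1 stands highest, and compound 2 lies below it by a margin beyond the usual scatter of this read-out. Within the data shown here, the two differ at more than one place, so no single-change step between them is available, and all that their values show is that compound 1 gives the higher inhibition.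

Compound 3, `Nc1ccccc1NC(=O)c1ccc(CSC(=S)N2CCN(c3ncccn3)CC2)cc1`, has not yet been measured in this assay. It differs from compound 1 in one place: pyrimidin-2-yl in place of cyclohexyl on an amine nitrogen in a ring. Among the measured compounds shown here, no pair of measured compounds shows this change, so the size of the step cannot be read off from the data and has to be judged from the change alone. The account expects a small step downward, a number 8.1 percentage points lower from compound 1 to compound 3 (within the scatter), of a size that may or may not exceed the scatter. The estimate for compound 3 in this assay is 68%, expected to fall between 50% and 82%.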

Compound 3, a percentage reported as inhibition, at one concentration (the size of the read-out at that concentration, not a potency): 73.9%
Beside the measured number, compound 3's estimate is 5.9 percentage points below it, within the range that was stated.
By their numbers in this assay, from the lowest: compound 2; then compounds 3 and 1 (each within the scatter of the next).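

In this assay, pyrimidin-2-yl in place of cyclohexyl on the amine nitrogen in the ring gives a number 2.2 percentage points lower from compound 1 to compound 3 (within the scatter), the first single-change step available in this series. At this position, therefore, the read-out does not separate a six-membered non-aromatic ring of carbon only, with 0 hydrogen-bond acceptors, from a six-membered aromatic ring with 2 hetero atoms and 2 hydrogen-bond acceptors. No measurement at hand bears on why these two groups read alike.

The compounds shown leave open whether phenyl, a small group such as methyl, or a longer chain ending in a carboxylic acid on this same nitrogen would also stay within the scatter of compound 1, so the tolerance seen here rests on only these two groups. Each number is also the size of the effect at a single concentration, so whether compound 1 and compound 3 would match in potency across a range of concentrations remains unanswered.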